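Acetyl in Place of Methyl on the Ring Amine

The compounds below may be only part of what the source reports. "The series", "measured", "known", "first", "only" and "open" are said of these compounds alone.

Of the compounds shown here, three sharing a fused core have been tested in an assay on HEK293 cells for negative allosteric modulation of metabotropic glutamate receptor 5 (Homo sapiens), read by FLIPR, with a stated time of 1 h; a higher number here means a weaker inhibitor, a lower number a stronger inhibitor. Compound 1 `COc1ccccc1C#Cc1nc2c(s1)C(=O)NCC2` carries a methoxy group on its phenyl ring and an unsubstituted lactam. In this assay compound 1 gives only a limit, > 10000 nM. Compound 2 `O=C1c2sc(C#Cc3ccccc3)nc2CN1C1CC1` has a cyclopropyl group on the lactam nitrogen, and in this assay compound 2 gives 23 nM. Compound 3 `CN1CCc2nc(C#Cc3ccccc3)sc2C1` differs from both in that its six-membered ring holds a methyl-bearing amine nitrogen rather than a lactam. In this assay compound 3 also gives only a limit, > 10000 nM. Two of the three values shown therefore sit at the limit of > 10000 nM in this assay, at which 2 of the 3 values shown sit, and only compound 2 gives a number.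

Compound 4 `CC(=O)N1CCc2nc(C#Cc3ccccc3)sc2C1` is the next compound. The change from compound 3 is acetyl in place of methyl on an amine nitrogen in a ring, so compound 4, like compound 2, carries a carbonyl on the ring nitrogen. No single-change step between measured compounds is shown, so the expected size of the step from compound 3 to compound 4 rests on this resemblance alone. Compound 3 stays at a limit. Because compound 2 gives 23 nM, compound 4 is expected to move toward a measurable number, by an at least 5.0-fold lower number from compound 3 to compound 4 (0.69 log units; beyond the scatter). The estimate for compound 4 in this assay is 2000 nM, with a range from 200 nM to 10000 nM, though a limit remains a real possibility.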

Compound 4, half-maximal inhibitory concentration: 90 nM
Beside the measured number, compound 4's estimate is 22-fold (1.35 log units) above it, and the stated range ends above it.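

On the amine nitrogen in the ring, methyl and acetyl are far from interchangeable in this assay: the change gives an at least 110-fold lower number from compound 3 to compound 4 (2.04 log units; beyond the scatter), and it takes this position from a limit to a measured number. The earlier compounds shown here differ from one another in more than one place, so they could not show that this position alone responds so strongly to the group it carries. The size of the step is itself only a bound, since compound 3 remains at a limit and gives no number: the limit of > 10000 nM in this assay, at which 2 of the 4 values shown sit.

The compounds shown leave open whether the carbonyl of the acetyl is what matters here, or whether another group on this nitrogen, such as a methyl carbamate, a methanesulfonyl group or a longer acyl chain like propionyl, would give a similar result. They also leave open how compound 4 would respond to a methoxy group on its phenyl ring, the feature carried by compound 1, whose other differences keep it from answering that question.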